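Furan-3-yl for thiophen-3-yl on the saturated ring carbon

The compounds below may be only part of what the source reports. "The series", "measured", "known", "first", "only" and "open" are said of these compounds alone.

Of the compounds shown here, three have been measured so far: compound 1 `CC1=NC(C)=C(C(=O)O)C(c2ccccc2[N+](=O)[O-])/C1=C(\O)OC/C=C/c1ccccc1`, compound 2 `CC1=NC(C)=C(C(=O)O)C(c2cccc(C)c2)/C1=C(\O)OC/C=C/c1ccccc1` and compound 3 `CC1=NC(C)=C(C(=O)O)C(c2ccsc2)/C1=C(\O)OC/C=C/c1ccccc1`. In a functional assay on IMR-32 cells for inhibition of Voltage-dependent N-type calcium channel subunit alpha-1B (Homo sapiens), read by calcium flux (on this read-out higher numbers stand for weaker inhibition and lower numbers for stronger inhibition), compound 1 gives 37000 nM, compound 2 gives 1800 nM and compound 3 gives 2900 nM. Compound 3 thus holds the second highest of the three numbers; its nearest neighbour is compound 2, and the step of a 1.6-fold higher number from compound 2 to compound 3 (0.21 log units; within the scatter) is within the scatter, while its furthest is compound 1, with a 13-fold lower number from compound 1 to compound 3 (1.11 log units; beyond the scatter). The other step, a 21-fold lower number from compound 1 to compound 2 (1.31 log units; beyond the scatter), is likewise large.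

Compound 4 `CC1=NC(C)=C(C(=O)O)C(c2ccoc2)/C1=C(\O)OC/C=C/c1ccccc1` is the next member and differs from compound 3 in one place: furan-3-yl in place of thiophen-3-yl on a saturated ring carbon. Within the data shown here, no measured step swaps thiophen-3-yl for furan-3-yl, so nothing bears on it directly. Among the measured compounds shown here, the only step involving thiophen-3-yl, a 1.6-fold higher number from compound 2 to compound 3 (0.21 log units; within the scatter), stays within the scatter; the large steps start from the 2-nitrophenyl of compound 1 and do not apply here. For compound 4 no step beyond the scatter is therefore expected in this assay, with a 1.0-fold higher number from compound 3 to compound 4 (0.01 log units; within the scatter) as the anticipated change. Compound 4 is estimated at 3000 nM, in the range 1200 nM to 8000 nM.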

Compound 4, half-maximal inhibitory concentration: 11000 nM
Compound 4: middle estimate off by 3.7-fold (0.56 log units), on the low side; measured number above the stated range.
By their numbers in this assay, from the lowest: compounds 2 and 3 (each within the scatter of the next); then compound 4; then compound 1.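

In this assay, the group on the saturated ring carbon responds to the exchange of one ring atom, sulfur for oxygen, at equal heavy-atom count and with the same counted acceptor (the step is a 3.8-fold higher number from compound 3 to compound 4 (0.58 log units; beyond the scatter)). Thiophen-3-yl and furan-3-yl are therefore not interchangeable here, and furan-3-yl falls apart from both phenyl groups (against 3-methylphenyl, a 6.1-fold higher number from compound 2 to compound 4 (0.79 log units; beyond the scatter); against 2-nitrophenyl, a 3.4-fold lower number from compound 1 to compound 4 (0.53 log units; beyond the scatter)). Nothing available accounts for the gap between the two five-membered rings.

Open, going by these compounds, is whether furan-2-yl or thiophen-2-yl would follow the same order as their 3-yl isomers. Also open, on these data alone, is whether the gap between compound 3 and compound 4 would survive with a methyl ester in place of the carboxy group.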